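The source may report more compounds than this note shows. Statements on the series, on what has been measured and on what is new or still open speak of the compounds shown alone.

Among the compounds with values here, in an assay on isolated protein for inhibition of thymidine kinase, cytosolic (Homo sapiens) (a lower number here means a stronger inhibitor, a higher number a weaker inhibitor), compound 2 `Cc1cn([C@H]2C[C@H](CN)[C@@H](COP(=O)(O)O)O2)c(=O)[nH]c1=O` gives 4700 nM, the lowest number among the two measured compounds; its only measured neighbour, compound 1 `Cc1cn([C@H]2C[C@H](CF)[C@@H](CO)O2)c(=O)[nH]c1=O`, gives in this assay 970000 nM, a gap far beyond the usual scatter. Compound 3 `Cc1cn([C@H]2C[C@H](CN)[C@@H](CO)O2)c(=O)[nH]c1=O` differs from compound 2 by a hydrogen atom in place of a group of 4 heavy atoms (3 oxygen, 1 phosphorus; no ring), on an oxygen on a saturated carbon. Within the data shown here, no measured pair shows this exact change on its own, so the size of the step can only be judged from what the two measured compounds show: compound 1, which also carries a hydroxyl at that place, stands far above compound 2 in this assay. The step from compound 2 to compound 3 is therefore expected to be large and toward a weaker inhibitor, estimated as a 43-fold higher number from compound 2 to compound 3 (1.63 log units; beyond the scatter). Compound 3 is thus expected to give about 200000 nM in this assay, within a range from 30000 nM to 1500000 nM.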

Compound 3, inhibition constant: 220000 nM
Compound 3: middle estimate off by 1.1-fold (0.04 log units), on the low side; low and high end bracket the measured number.
By their numbers in this assay, from the lowest: compound 2; then compound 3; then compound 1.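

In this assay, a hydrogen atom in place of the group of 4 heavy atoms (3 oxygen, 1 phosphorus) on the oxygen on a saturated carbon can now be read as a single change, and it gives a large step toward a weaker inhibitor (a 47-fold higher number from compound 2 to compound 3 (1.67 log units; beyond the scatter)). With a hydroxyl at that place in both compounds, amino in place of fluoro on the saturated chain carbon bound to a saturated ring carbon gives only a modest step toward a stronger inhibitor (a 4.4-fold lower number from compound 1 to compound 3 (0.64 log units; beyond the scatter)). Nothing measured here explains either step.

The compounds shown leave open how a methyl or an acetyl on that oxygen would compare with the hydrogen atom and the larger group. They also leave open how a hydroxyl or an azide on the chain carbon would stand against amino and fluoro.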